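Swapping Fluoro for Methoxy on the Aryl Triazole

The source may hold more compounds than are shown below. What is called first, only, known or untested is meant among the compounds shown, and "the series" means these compounds.

Of the compounds shown here, three have been tested in a functional assay on MCF7 cells (Homo sapiens) for cytotoxicity, read by MTT assay, with a stated time of 4 days; on this read-out higher numbers stand for weaker inhibition and lower numbers for stronger inhibition. Compound 1 `C=C1C[C@]23C[C@@]1(O)CC[C@H]2c1cc(Br)c(O)c(C)c1[C@@H]3Cn1cc(-c2ccc(C)cc2)nn1` gives > 20000 nM, which is a limit of the assay rather than a number. Compound 2 `Cc1c(O)ccc2c1[C@H](Cn1cc(-c3ccc(F)cc3)nn1)[C@@]13CC(=O)[C@@](C)(CC[C@@H]21)C3` gives > 20000 nM, again a limit and not a number. Among the compounds with values here, compound 3 `C=C1C(=O)[C@]23C[C@@]1(O)CC[C@H]2c1ccc(OS(=O)(=O)c2ccc(C)cc2)c(C)c1[C@@H]3Cn1cc(-c2ccc(F)cc2)nn1` gives 330 nM, the only number among the three. Compound 3 thus stands alone with a measured value, the other two results being (the limit of > 20000 nM in this assay, at which 2 of the 3 values shown sit). Compound 4 `C=C1C(=O)[C@]23C[C@@]1(O)CC[C@H]2c1ccc(OS(=O)(=O)c2ccc(C)cc2)c(C)c1[C@@H]3Cn1cc(-c2ccc(OC)cc2)nn1` differs from compound 3 in one place: methoxy in place of fluoro on an aromatic carbon. Within the data shown here, no step between two measured compounds is available to guide this change, so the expected step is small, within the usual scatter, in either direction. Compound 4 is estimated at 400 nM, in a range from 150 nM to 1200 nM, an expected step of a 1.2-fold higher number from compound 3 to compound 4 (0.08 log units; within the scatter).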

Compound 4, half-maximal inhibitory concentration: 310 nM
Compound 4: middle estimate off by 1.3-fold (0.11 log units), on the high side; measured number inside the range.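

Going from 4-fluorophenyl to 4-methoxyphenyl gives a 1.1-fold lower number from compound 3 to compound 4 (0.03 log units; within the scatter) in this assay, the first step measured between two compounds that differ in one place. The two compounds read alike, so at this position on the ring, methoxy serves as well as fluoro in this assay. Nothing measured here says why the two groups read alike. Still open, from the compounds shown here alone, is whether an amine, a carboxylic acid or a longer chain at the same position would also keep the value. A single pair also cannot show how far this tolerance extends.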